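The source may report more compounds than this note shows. Statements on the series, on what has been measured and on what is new or still open speak of the compounds shown alone.

Three compounds have so far been measured in an assay on Sf9 cells for inhibition of protein deacetylase HDAC6 (Homo sapiens), read by fluorescence, with a stated time of 40 min, tested at 100 nM; a lower number here means less inhibition, a higher number more inhibition at the concentration tested (going by the name of the read-out):

Compound 1 `O=C(NO)c1ccc(NCc2nc(-c3ccccc3)nn2-c2cccc(Cl)c2)cc1`: 62.3%
Compound 2 `O=C(NO)c1ccc(NCc2nc(-c3ccccc3)nn2-c2ccccc2)cc1`: 72.6%
Compound 3 `CC(C)c1ccc(-n2nc(-c3ccccc3)nc2CNc2ccc(C(=O)NO)cc2)cc1`: 52.6%

Compound 3 stands lowest of these three numbers. Its nearest neighbour is compound 1, the step being a number 9.7 percentage points lower from compound 1 to compound 3 (within the scatter), which sits within the scatter. Its furthest neighbour is compound 2, where the step is a number 20 percentage points lower from compound 2 to compound 3 (beyond the scatter), a modest change beyond the scatter.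

The next compound, compound 4 `Cc1cc(C)cc(-n2nc(-c3ccccc3)nc2CNc2ccc(C(=O)NO)cc2)c1`, differs from compound 3 in one place: 3,5-dimethylphenyl in place of 4-isopropylphenyl on an aromatic nitrogen. Going by the values given here, two measured steps bear on this change. The step of a number 20 percentage points lower from compound 2 to compound 3 (beyond the scatter) shows that adding an isopropyl on the phenyl attached to the aromatic nitrogen cost a modest amount of inhibition, while a number 10.3 percentage points higher from compound 1 to compound 2 (beyond the scatter) shows that a bare phenyl gave more inhibition than a chloro-bearing one. Compound 4 removes the isopropyl but brings in two methyl groups on the same ring, so the net effect is uncertain; a small rise from compound 3 toward the level of compound 2 seems most likely, though it may stay within the scatter.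

The author therefore expects compound 4 to reach about 58% in this assay, within a range from 42% to 74%, an expected step of a number 5.4 percentage points higher from compound 3 to compound 4 (within the scatter).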

Compound 4, a percentage reported as inhibition, at one concentration (the size of the read-out at that concentration, not a potency): 49.8%
Compound 4: the middle estimate sits 8.2 percentage points above what was measured; the measured number falls inside the stated range.
By their numbers in this assay, from the lowest: compounds 4, 3 and 1 (each within the scatter of the next, the first and the last beyond it); then compound 2.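

In this assay the exchange of 4-isopropylphenyl for 3,5-dimethylphenyl on the aromatic nitrogen gives a number 2.8 percentage points lower from compound 3 to compound 4 (within the scatter), so these two differently substituted rings cannot be told apart here, even though one carries a single large group and the other two methyl groups. The bare phenyl stays clear of the new ring, with a number 22.8 percentage points lower from compound 2 to compound 4 (beyond the scatter), a step of much the same size as a number 20 percentage points lower from compound 2 to compound 3 (beyond the scatter); all three substituted rings now read below compound 2, and none of the compounds shown goes against this. The new compound also adds a separation the earlier ones lacked, since a number 12.5 percentage points lower from compound 1 to compound 4 (beyond the scatter) is a step that lies beyond the scatter, whereas a number 9.7 percentage points lower from compound 1 to compound 3 (within the scatter) does not.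

From the compounds shown here alone, it remains open whether any group on this ring can match the bare phenyl, for instance a methoxy, a fluoro or an amine, and whether a single methyl would already bring the number down as far as two do. Nothing in hand accounts for why the substituted rings give these numbers.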